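The source may report more compounds than this note shows. Statements on the series, on what has been measured and on what is new or still open speak of the compounds shown alone.

Measured compounds:
compound 1 `O=S(=O)(NCCCNCc1ccc(C(F)(F)F)cc1)c1cc(C(F)(F)F)cc(C(F)(F)F)c1`: 2800 nM
compound 2 `CN(CCCNS(=O)(=O)c1cc(C(F)(F)F)cc(C(F)(F)F)c1)Cc1ccccc1`: 28000 nM
compound 3 `O=S(=O)(NCCCNCc1cccc(Cl)c1)c1cc(C(F)(F)F)cc(C(F)(F)F)c1`: 2200 nM

In a functional assay on A2780 cells (Homo sapiens) for inhibition, read by MTT assay, with a stated time of 72 h (on this read-out higher numbers stand for weaker inhibition of growth and lower numbers for stronger inhibition of growth), compound 3 carries the lowest of the three numbers. Compound 1 sits within the scatter of it (a 1.3-fold lower number from compound 1 to compound 3 (0.10 log units; within the scatter)), while compound 2 lies well apart (a 13-fold lower number from compound 2 to compound 3 (1.10 log units; beyond the scatter)). Compound 4 `COc1cccc(CNCCCNS(=O)(=O)c2cc(C(F)(F)F)cc(C(F)(F)F)c2)c1` differs from compound 3 only by methoxy in place of chloro on an aromatic carbon, that is, 3-methoxybenzyl in place of 3-chlorobenzyl. Among the measured compounds shown here, the one measured step that touches this aromatic ring is a 1.3-fold lower number from compound 1 to compound 3 (0.10 log units; within the scatter), a swap of the whole ring substituent that stayed within the scatter; the large step of a 13-fold lower number from compound 2 to compound 3 (1.10 log units; beyond the scatter) concerns the amine and does not bear on the ring. A step within the scatter is therefore expected, in no firm direction, a 1.1-fold higher number from compound 3 to compound 4 (0.06 log units; within the scatter). Compound 4 is estimated at 2500 nM, with a range of 1000 nM to 6500 nM.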

Compound 4, concentration for 50% growth inhibition: 1600 nM
Estimate against measurement, compound 4: 1.6-fold (0.19 log units) above; measured number inside the range.
By their numbers in this assay, from the lowest: compounds 4, 3 and 1 (each within the scatter of the next); then compound 2.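

In this assay, methoxy in place of chloro on an aromatic carbon, meta to a large group, gives a 1.4-fold lower number from compound 3 to compound 4 (0.14 log units; within the scatter), so this position accepts a change from a halogen to an oxygen-linked group with an added hydrogen-bond acceptor and no step beyond the scatter. Against the 4-(trifluoromethyl)phenyl analogue, the step also stays within the scatter: a 1.8-fold lower number from compound 1 to compound 4 (0.24 log units; within the scatter). The large gap to the benzyl(methyl)amino compound persists with methoxy on the ring: an 18-fold lower number from compound 2 to compound 4 (1.24 log units; beyond the scatter).

On these data alone, it remains open whether that gap belongs to the methyl on the amine nitrogen or to the bare ring of compound 2, and how a nitrile or hydroxyl would behave at this ring position. No measured evidence accounts for any of these steps.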